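The source may report more compounds than this note shows. Statements on the series, on what has been measured and on what is new or still open speak of the compounds shown alone.

In an ADME assay on microsomes from liver (Homo sapiens) for metabolic stability (on this read-out higher numbers stand for fast clearance and lower numbers for slow clearance), compound 1 `CCCC(Oc1ccc(-n2cc(OC)cn2)cc1)c1ccc(C(=O)NCCC(=O)O)cc1` gives < 8 mL/min/kg as a limit of the assay and not a number. Among the compounds with values here, the only other compound measured, compound 2 `O=C(O)CCNC(=O)c1ccc(C(Oc2ccc(-n3cc(C(F)(F)F)cn3)cc2)C2CC2)cc1`, likewise gives < 8 mL/min/kg as a limit. Compound 3 `CCCC(Oc1ccc(-n2cc(C(=O)N(C)C)cn2)cc1)c1ccc(C(=O)NCCC(=O)O)cc1` keeps the core of compound 1 but carries dimethylcarbamoyl in place of methoxy on an aromatic carbon of the five-membered ring. Within the data shown here, no measured step shows what this swap does to clearance. The expected change is none beyond the usual scatter, with a number no lower from compound 1 to compound 3 (the limit leaves the size open) as the estimate. For compound 3 the expected clearance is 8 mL/min/kg within a range from 4 mL/min/kg to 15 mL/min/kg as an estimate.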

Compound 3, clearance: < 13 mL/min/kg
Compound 3 gave a limit, no number (the forecaster's own chance of this, stated with the estimate: 60%); the middle value lies beyond the limit too.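

Compound 1 and compound 3 both give only limits of the assay, not numbers, so the step between them cannot be read. The compounds shown leave open whether dimethylcarbamoyl in place of methoxy changes clearance at all.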